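The source may report more compounds than this note shows. Statements on the series, on what has been measured and on what is new or still open speak of the compounds shown alone.

In a functional assay on DU-145 cells (Homo sapiens) for inhibition, read by trypan blue exclusion, with a stated time of 96 h (a higher number here means a weaker inhibitor of growth, a lower number a stronger inhibitor of growth), compound 1 `COc1cc(OC)c(/C=C(/SCc2ccc(Cl)cc2)C(=O)c2ccc(Br)cc2)c(OC)c1` gives 1000 nM as its result, and compound 3 `COc1cc(OC)c(/C=C(/SCc2ccc(F)cc2)C(=O)c2ccc(Cl)cc2)c(OC)c1` gives 10000 nM as its result. Compound 2 `COc1cc(OC)c(/C=C(/Sc2ccc(C)cc2)C(=O)c2ccc(Cl)cc2)c(OC)c1` gives > 100000 nM as its result, and this is a limit, not a number. Its place on the scale is therefore known only as the limit of > 100000 nM in this assay, at which 1 of the 3 values shown sits, in the series.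

Compound 4 `COc1cc(OC)c(/C=C(/Sc2ccc(C)cc2)C(=O)c2ccc(Br)cc2)c(OC)c1` differs from compound 2 in a single swap, bromo in place of chloro on an aromatic carbon on the ring, with bromo in place of chloro on an aromatic carbon. Among the measured compounds shown here, the one measured step, an at least 10-fold lower number from compound 2 to compound 3 (1.00 log units; beyond the scatter) in size, changes the group on sulfur and leaves the chloro untouched, so it bears on this swap only indirectly. A bromo and chloro comparison is also blurred: compound 3, with chloro, reads 10000 nM and compound 1, with bromo, reads 1000 nM, but these two also differ in a second place.

Only a slight move towards a lower number is therefore expected, and the estimated change is an at least 1.6-fold lower number from compound 2 to compound 4 (0.22 log units; that floor lies within the scatter) in this assay overall. For compound 4 the expected value is 60000 nM with an estimated range of 15000 nM to 100000 nM in this assay, and the result may again be only a limit.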

Compound 4, concentration for 50% growth inhibition: > 100000 nM
Compound 4: no number, only a limit (the forecaster's own chance of this, stated with the estimate: 55%); middle value at least 1.6-fold (0.22 log units) away from the limit.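

In this assay compound 4 gives > 100000 nM, which is a limit and not a number; compound 2 is also a limit, so the step from chloro to bromo cannot be read: the limit of > 100000 nM in this assay, at which 2 of the 4 values shown sit.

With 4-methylphenyl on the sulfur, neither chloro nor bromo gives a compound a measured number in this series. The group on sulfur, by contrast, again marks a clear difference, now with bromo on the other ring: an at least 100-fold higher number from compound 1 to compound 4 (2.00 log units; beyond the scatter), which parallels the step seen with chloro, an at least 10-fold lower number from compound 2 to compound 3 (1.00 log units; beyond the scatter).

On these data alone, whether bromo and chloro differ when a benzyl group sits on the sulfur stays open, since compound 1 and compound 3 also differ in a second place. Also open, as far as these compounds go, is how an amine or a carboxylic acid would read in place of the halogen.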